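Methylsulfonyl for carboxy on a meta-substituted phenyl

The source may report more compounds than this note shows. Statements on the series, on what has been measured and on what is new or still open speak of the compounds shown alone.

Three compounds share a core and are compared in an assay for inhibition of Fatty-acid amide hydrolase 1 (Rattus norvegicus); on this read-out lower numbers stand for stronger inhibition and higher numbers for weaker inhibition. Compound 1 `O=C(CCCCCCc1ccccc1C(=O)O)c1ncc(-c2ccccn2)o1` carries a 2-carboxyphenyl at the end of the saturated chain. In this assay compound 1 gives only the limit > 600 nM, which is not a number. Compound 2 `O=C(O)c1cccc(CCCCCCC(=O)c2ncc(-c3ccccn3)o2)c1` differs from compound 1 in that the change 3-carboxyphenyl in place of 2-carboxyphenyl on a saturated chain carbon, six bonds along the chain from a carbonyl carbon occurs, so the two cores have the same atoms joined differently. For compound 2 this assay likewise gives only the limit > 600 nM. The step that the two limits leave unreadable from compound 1 to compound 2 therefore cannot be read, since both values sit at the limit of > 600 nM in this assay, at which 2 of the 3 values shown sit.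

Compound 3 `CS(=O)(=O)c1ccccc1CCCCCCC(=O)c1ncc(-c2ccccn2)o1` is made from compound 1 by methylsulfonyl in place of carboxy on an aromatic carbon. In this assay compound 3 gives 37 nM, so the step is an at least 16-fold lower number from compound 1 to compound 3 (1.20 log units; beyond the scatter).

Compound 4 `CS(=O)(=O)c1cccc(CCCCCCC(=O)c2ncc(-c3ccccn3)o2)c1` has not yet been measured. It stands to compound 2 as compound 3 stands to compound 1, by the change (methylsulfonyl in place of carboxy on an aromatic carbon). The two places are not the same word for word: in compound 1 the methylsulfonyl enters ortho to a large group, in compound 2 meta to a large group, so this is the same kind of change rather than the same change. The expectation rests on compound 3, whose value 37 nM came from this change, and on compound 2, whose value is only the limit > 600 nM. For compound 4 the step is estimated as an at least 10-fold lower number from compound 2 to compound 4 (1.00 log units; beyond the scatter). Compound 4 is expected to give about 60 nM, between 15 nM and 400 nM.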

Compound 4, inhibition constant: 1.3 nM
For compound 4 the middle estimate is 46-fold (1.66 log units) above the measured one; measured number below the stated range.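

In this assay the change of carboxy to methylsulfonyl on the core of compound 2 gives a large shift in the same direction as on the core of compound 1 (an at least 460-fold lower number from compound 2 to compound 4 (2.66 log units; beyond the scatter)), so across these two cores, which differ only in where the group sits on the phenyl ring, the direction of the change carried over. Compound 2 gives only a limit (> 600 nM), which is not a number, so the step between the two carboxy compounds cannot be read, and the step to compound 4 has an open end. This pair therefore shows that the direction of the change held, not that its size was carried from one core to the other, and the comparison of the two steps stays unsettled: (the limit of > 600 nM in this assay, at which 2 of the 4 values shown sit; (the same change on two cores in this assay, an at least 16-fold lower number (1.20 log units; beyond the scatter) from compound 1 to compound 3 and an at least 460-fold lower number (2.66 log units; beyond the scatter) from compound 2 to compound 4; the limit leaves it open whether they differ)).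

The compounds shown leave open whether a different group in the same place, such as a nitrile, a primary sulfonamide or an amide, would give a similar shift. They also leave open whether the shift would persist with a shorter or longer chain between the phenyl ring and the carbonyl.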